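The source may hold more compounds than are shown below. What is called first, only, known or untested is meant among the compounds shown, and "the series" means these compounds.

Measured compounds in a functional assay on MCF7 cells (Homo sapiens) for antiproliferative activity, read by MTT assay, with a stated time of 48 h; a higher number here means a weaker inhibitor, a lower number a stronger inhibitor:
compound 1, `CCOC(=O)CN(Cc1ccccc1)c1nc(NCc2ccccc2)ncc1[N+](=O)[O-]`, gives > 100000 nM, which is a limit of the assay and not a number.
compound 2, `COC(=O)CN(C)c1nc(NCc2ccccc2)ncc1[N+](=O)[O-]`, gives 85900 nM.
compound 3, `CCOC(=O)CN(Cc1ccccc1)c1nc(Nc2cc(OC)c(OC)c(OC)c2)ncc1[N+](=O)[O-]`, gives > 100000 nM, which is a limit of the assay and not a number.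

Compound 3 therefore stands at the upper boundary of what this assay reports. Among the compounds with values here, compound 1 sits at the same limit, as recorded in the limit of > 100000 nM in this assay, at which 2 of the 3 values shown sit, and the single change from benzyl to 3,4,5-trimethoxyphenyl on a nitrogen on an aromatic ring, a step that the two limits leave unreadable from compound 1 to compound 3, cannot be sized because both ends are limits. Within the data shown here, compound 2, the only compound with a number, is a weak inhibitor as well.

Compound 4, `CCOC(=O)CN(Cc1ccccc1)c1nc(Nc2cccc(OC)c2)ncc1[N+](=O)[O-]`, differs from compound 3 by 3-methoxyphenyl in place of 3,4,5-trimethoxyphenyl on a nitrogen on an aromatic ring, in words: 3-methoxyphenyl in place of 3,4,5-trimethoxyphenyl on a nitrogen on an aromatic ring. Among the measured compounds shown here, no measured step involves this change, and the one step touching the same nitrogen is unreadable. With compound 3 at the limit, the expected step from compound 3 to compound 4 is a number no higher from compound 3 to compound 4 (the limit leaves the size open), meaning no readable change is expected. Compound 4 is accordingly estimated at 100000 nM in this assay, with a plausible range from 30000 nM to 300000 nM, and a limit rather than a number is the likelier outcome.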

Compound 4, half-maximal inhibitory concentration: > 100000 nM
Compound 4: a limit, no number; the forecaster's own chance of this, stated with the estimate: 60%; the middle value sits exactly at the limit.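

Compound 4 gives > 100000 nM in this assay, which is a limit of the assay and not a number. The steps to compound 4 from compound 3 and from compound 1 cannot be read, as both ends of each are limits: the limit of > 100000 nM in this assay, at which 3 of the 4 values shown sit.

The compounds shown leave open whether benzyl, 3-methoxyphenyl and 3,4,5-trimethoxyphenyl on this nitrogen differ at all in this assay.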